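This account rests on a few compounds, and the source may have more. Where it says the series, first, only, none or still open, it means among the compounds named here.

Measured compounds:
Compound 1, `COc1cc2c(Oc3ccc(NC(=O)c4nn(-c5ccccc5C)c(=O)cc4C)cc3F)ccnc2cc1OCCCN1CCCCC1`: in a functional assay on MKN-45 cells (Homo sapiens) for inhibition, read by MTT assay, with a stated time of 72 h (on this read-out lower numbers stand for stronger inhibition and higher numbers for weaker inhibition), compound 1 gives 1310 nM.
Compound 2, `COc1cc2c(Oc3ccc(NC(=O)c4nn(-c5ccccc5C(F)(F)F)c(=O)cc4C)cc3F)ccnc2cc1OCCCN1CCCCC1`: in this assay compound 2 gives 90 nM.
Compound 3, `COc1cc2c(Oc3ccc(NC(=O)c4nn(-c5ccccc5C(F)(F)F)c(=O)cc4C)cc3F)ccnc2cc1OCCCN1CCN(C)CC1`: in this assay compound 3 gives 40 nM.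

Among these three numbers compound 2 stands second highest. Its nearest neighbour is compound 3, reached by a 2.3-fold lower number from compound 2 to compound 3 (0.35 log units; beyond the scatter), and its furthest is compound 1, separated by a 15-fold lower number from compound 1 to compound 2 (1.16 log units; beyond the scatter).

The unmeasured compound 4, `COc1cc2c(Oc3ccc(NC(=O)c4nn(-c5cccc(F)c5)c(=O)cc4C)cc3F)ccnc2cc1OCCCN1CCCCC1`, differs from compound 2 in one place: 3-fluorophenyl in place of 2-(trifluoromethyl)phenyl on an aromatic nitrogen. Among the measured compounds shown here, only one measured step touches the group on that aromatic nitrogen, namely a 15-fold lower number from compound 1 to compound 2 (1.16 log units; beyond the scatter), and it was large: swapping the small group there changed the number a long way. For the measured compounds named here, compound 4 carries neither the trifluoromethyl of compound 2 nor the methyl of compound 1, but a 3-fluorophenyl; no measured pair covers that group, so the size of its effect is uncertain. Because a 15-fold lower number from compound 1 to compound 2 (1.16 log units; beyond the scatter) shows how much this group can matter, the number for compound 4 is expected to rise, by about a 6.7-fold higher number from compound 2 to compound 4 (0.82 log units; beyond the scatter). Compound 4 is therefore estimated at 600 nM, with a range from 150 nM to 2500 nM.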

Compound 4, half-maximal inhibitory concentration: 130 nM
Compound 4: middle estimate off by 4.6-fold (0.66 log units), on the high side; the measured number lies below the stated range.
By their numbers in this assay, from the lowest: compound 3; then compounds 2 and 4 (each within the scatter of the next); then compound 1.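

In this assay, a low number on this aromatic nitrogen does not depend on the trifluoromethyl group: with a 1.4-fold higher number from compound 2 to compound 4 (0.16 log units; within the scatter), 3-fluorophenyl and 2-(trifluoromethyl)phenyl cannot be told apart, even though the entering group is smaller and carries its substituent at a different place on the phenyl. With a 10-fold lower number from compound 1 to compound 4 (1.00 log units; beyond the scatter) for the other pair, the 2-methylphenyl of compound 1 now stands alone among these three groups as the one giving a clearly higher number. No available evidence explains this difference.

The compounds shown do not reveal how an unsubstituted phenyl or a methoxyphenyl on that nitrogen would behave. Going by these compounds, the change from piperidin-1-yl to 4-methylpiperazin-1-yl is also seen only alongside 2-(trifluoromethyl)phenyl, so its effect alongside 3-fluorophenyl remains open.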